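The source may report more compounds than this note shows. Statements on the series, on what has been measured and on what is new or still open speak of the compounds shown alone.

Compound 1 `CCOC(=O)C(CCCCCN)CSC(C)=O` gives 310000 nM in an assay on isolated protein for inhibition of carboxypeptidase B2 (Homo sapiens), read by spectrophotometry, with stated times of 10 min and 30 min (a higher number here means a weaker inhibitor, a lower number a stronger inhibitor), the highest number of the three measured. Compound 3 `CC(=O)SCC(CCCCCN)C(=O)O` gives 3800 nM and compound 2 `NCCCCCC(C[Se]C(=O)CCc1ccccc1)C(=O)O` gives 2000 nM. Within the data shown here, the only single-point step measured so far, an 82-fold lower number from compound 1 to compound 3 (1.91 log units; beyond the scatter), concerns the ethyl on the oxygen and not the sulfur. Among the measured compounds shown here, compound 4 `CCOC(=O)C(CS)CCCCCN` differs from compound 1 by hydrogen in place of acetyl on a sulfur, the ethyl on the oxygen staying in place; compound 2 and compound 3 differ from each other in more than one place and so supply no further step. For the measured compounds named here, no measured step bears directly on this change in this assay; only the position of compound 1 at the top suggests room downward. The expected step is a 16-fold lower number from compound 1 to compound 4 (1.19 log units; beyond the scatter), a lower number with wide uncertainty. Compound 4 is estimated at 20000 nM, between 1500 nM and 250000 nM.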

Compound 4, half-maximal inhibitory concentration: 62000 nM
Compound 4: the middle estimate sits 3.1-fold (0.49 log units) below what was measured; the range from low to high includes it.
By their numbers in this assay, from the lowest: compounds 2 and 3 (each within the scatter of the next); then compound 4; then compound 1.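

Read in this assay the change on the sulfur counts on its own with the ethyl on the oxygen still in place: the step is a 5.0-fold lower number from compound 1 to compound 4 (0.70 log units; beyond the scatter) and lies beyond the scatter. It is smaller than the step at the oxygen, which is an 82-fold lower number from compound 1 to compound 3 (1.91 log units; beyond the scatter) and so remains the larger of the two changes made on compound 1. No measured evidence is available to explain this step.

Open, from the compounds shown here alone, is whether hydrogen on both the sulfur and the oxygen goes further than either single change. Also open, going by these compounds, is how a methyl group on the sulfur, or an amide in place of the ethyl ester, would read.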